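The compounds below may be only part of what the source reports. "The series", "measured", "known", "first", "only" and "open" are said of these compounds alone.

Measured so far:

Compound 1 `Nc1ncc(-c2cccc(Cl)c2)c(-c2ccccc2)n1`; in an assay on CHO cells for displacement of a labelled ligand from adenosine receptor A1 (Homo sapiens), read by scintillation counting, with a stated time of 1 h, tested at 1 uM (a higher number here means more inhibition at the concentration tested (going by the name of the read-out), a lower number less inhibition), compound 1 gives > 80%, which is a limit of the assay and not a number.
Compound 2 `Nc1ncc(-c2ccc(Cl)cc2)c(-c2ccccc2)n1`; here compound 2 gives 41%.
Compound 3 `COc1cccc(-c2cnc(N)nc2-c2ccccc2)c1`; compound 3 gives > 80%, again a limit of the assay.

Compound 1 and compound 3 differ by one change, (methoxy in place of chloro on an aromatic carbon). The step that the two limits leave unreadable from compound 1 to compound 3 cannot be sized because both values sit at the limit of > 80% in this assay, at which 2 of the 3 values shown sit. Compound 2 has the same atoms as compound 1 joined differently; the difference between the two cores is not broken down here. Among the three values, only compound 2 gives a number, and that number is clearly below the limit.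

Compound 4 `COc1ccc(-c2cnc(N)nc2-c2ccccc2)cc1` stands to compound 2 as compound 3 stands to compound 1: the same kind of change, (methoxy in place of chloro on an aromatic carbon), though here the place is para to a large group rather than meta to a large group. In this assay compound 4 is expected to give 45%, likely within 20% to 75%. The expected step of a number 4 percentage points higher from compound 2 to compound 4 (within the scatter) is estimated to be small, resting on compound 2 and its value 41%, since the measured step that the two limits leave unreadable from compound 1 to compound 3 gives no readable size to carry over.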

Compound 4, a percentage reported as inhibition, at one concentration (the size of the read-out at that concentration, not a potency): 56%
Estimate against measurement, compound 4: 11 percentage points below, and the stated range covers the measured number.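

In this assay, methoxy in place of chloro, para to a large group, gives a number 15 percentage points higher from compound 2 to compound 4 (beyond the scatter), so on this core the change brings a modest gain in inhibition. That is a single readable step, however, and one step cannot show that the change would have the same size or even the same direction on another core. The same change on the core of compound 1, leading to compound 3, cannot be read, since both values are limits of the assay and not numbers: the limit of > 80% in this assay, at which 2 of the 4 values shown sit.

The compounds shown leave open how other groups at this place on the core of compound 2 would behave, such as an amine, a carboxylic acid or a longer chain like ethoxy. Among these compounds, they also leave open whether any of these would give a step of similar size, as methoxy and chloro are the only two groups compared there.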